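A few compounds are considered here, and "the series" means these few. Any claim that something is new, unique, unknown or untested is made for them only; others in the source may bear on it.

Working notes on the series. Three compounds sharing the core of compound 1 have been run in a functional assay on SNB-19 cells (Homo sapiens) for inhibition, read by sulforhodamine B assay, with a stated time of 48 h, tested at 10 uM; on this read-out lower numbers stand for a stronger effect and higher numbers for a weaker effect at the one concentration tested. Compound 1 `COc1cc2cc(Oc3ccc(NC(=O)Nc4ccccc4)cc3)c(C)nc2cc1OC` gives 94.8%; compound 2 `COc1cc2cc(Oc3ccc(NC(=O)Nc4ccc(C)cc4)cc3)c(C)nc2cc1OC` gives 97.1%; compound 3 `COc1cc2cc(Oc3ccc(NC(=O)Nc4ccc(C(F)(F)F)cc4)cc3)c(C)nc2cc1OC` gives 93.5%. Compound 3 holds the lowest of the three numbers, but a number 1.3 percentage points lower from compound 1 to compound 3 (within the scatter) and a number 3.6 percentage points lower from compound 2 to compound 3 (within the scatter) both lie within the scatter, so nothing separates the three compounds on this read-out; the remaining step, a number 2.3 percentage points higher from compound 1 to compound 2 (within the scatter), is within the scatter as well.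

Compound 4 `COc1cc2cc(Oc3ccc(NC(=O)Nc4cccc(C(F)(F)F)c4)cc3)c(C)nc2cc1OC` has not yet been measured. It differs from compound 3 only in 3-(trifluoromethyl)phenyl in place of 4-(trifluoromethyl)phenyl on an amide-type nitrogen. None of the three measured steps concerns this kind of change; they only vary which group sits on the phenyl ring, and each stayed within the scatter. Because the measured steps of a number 1.3 percentage points lower from compound 1 to compound 3 (within the scatter) and a number 3.6 percentage points lower from compound 2 to compound 3 (within the scatter) are both small, a step of no more than the scatter is expected from compound 3 to compound 4, in no particular direction: a number 0.5 percentage points higher from compound 3 to compound 4 (within the scatter). Compound 4 is therefore estimated at 94% in this assay, with a range from 84% to 102%.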

Compound 4, a percentage reported as activity, at one concentration (the size of the read-out at that concentration, not a potency): 31.4%
Compound 4: middle estimate off by 62.6 percentage points, on the high side, outside the stated range (below it).
By their numbers in this assay, from the lowest: compound 4; then compounds 3, 1 and 2 (each within the scatter of the next).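

In this assay, among the compounds shown here, 3-(trifluoromethyl)phenyl in place of 4-(trifluoromethyl)phenyl on the amide-type nitrogen gives a number 62.1 percentage points lower from compound 3 to compound 4 (beyond the scatter) with the same atoms on both sides, so in this pair the place of the trifluoromethyl group on the phenyl ring decides the read-out, which the earlier steps could not show as they only varied which group sat on the ring. The replacement of hydrogen by trifluoromethyl on an aromatic carbon accordingly has no single size here: it is a number 1.3 percentage points lower from compound 1 to compound 3 (within the scatter) in one case and a number 63.4 percentage points lower from compound 1 to compound 4 (beyond the scatter) in the other. Against the 4-methylphenyl urea the picture is the same, with a number 65.7 percentage points lower from compound 2 to compound 4 (beyond the scatter) and compound 4 standing apart from the other three compounds.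

Nothing at hand bears on the reason for this step. From the compounds shown here alone, it remains open whether the effect belongs to trifluoromethyl itself or also appears with 3-methylphenyl, 3-chlorophenyl or 3-methoxyphenyl on the same nitrogen, and the single concentration gives no potency for compound 4.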